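The source may report more compounds than this note shows. Statements on the series, on what has been measured and on what is new or still open speak of the compounds shown alone.

The measured compounds: compound 1 `COc1cc(OC)c(C(=O)/C=C/c2ccc(Cl)cc2)c(OC)c1` and compound 2 `COc1cc(O)c(C(=O)/C=C/c2ccccc2SC)c(OC)c1`.

In an ADME assay on cells (Fibroblast, Homo sapiens) for cytotoxicity, with a stated time of 48 h (on this read-out higher numbers stand for weaker inhibition and lower numbers for stronger inhibition), compound 1 gives > 20000 nM, which is a limit of the assay rather than a number. Compound 2 gives > 20000 nM in this assay, again a limit. Both shown values sit at this limit (the limit of > 20000 nM in this assay, at which 2 of the 2 values shown sit), so compound 1 stands where every value here stands. Compound 3 `COc1cc(OC)c(C(=O)/C=C/c2ccc(F)cc2)c(OC)c1` differs from compound 1 by fluoro in place of chloro on an aromatic carbon. Among the compounds with values here, no step between measured compounds exists here to guide the size. The step that the limit leaves unreadable from compound 1 to compound 3 is estimated to be small, within the usual scatter. Compound 3 is therefore expected to give 30000 nM, between 15000 nM and 60000 nM, most likely again only a limit.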

Compound 3, half-maximal inhibitory concentration: > 20000 nM
Compound 3: a limit, no number; the forecaster's own chance of this, stated with the estimate: 85%; the middle value does not contradict the limit.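

Compound 1 and compound 3 both give only a limit, so no step can be read for fluoro in place of chloro: the limit of > 20000 nM in this assay, at which 3 of the 3 values shown sit.

The compounds shown leave open what change to the shared core would give an actual number in this assay rather than a limit.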